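Chloro in place of trifluoromethyl: a small step expected

The source may report more compounds than this note shows. Statements on the series, on what has been measured and on what is new or still open speak of the compounds shown alone.

Measured compounds:
compound 1, `Oc1nc2nonc2nc1Nc1ccccc1F`, gives 12500 nM in an assay on mitochondria from L6 cells (Rattus norvegicus) for activation, with a stated time of 90 min; on this read-out higher numbers stand for an effect only at larger amounts of compound and lower numbers for an effect already at smaller amounts
compound 2, `Oc1nc2nonc2nc1Nc1ccccc1`, gives 66700 nM in this assay
compound 3, `Oc1nc2nonc2nc1Nc1ccccc1C(F)(F)F`, gives 10600 nM in this assay

Compound 3 has the lowest number of the three. Compound 1 sits nearest to it, and the step between them is a 1.2-fold lower number from compound 1 to compound 3 (0.07 log units; within the scatter), so the two cannot be told apart. Compound 2, which carries hydrogen where the other two carry a fluorine-bearing group, lies furthest away: a 6.3-fold lower number from compound 2 to compound 3 (0.80 log units; beyond the scatter), and likewise a 5.3-fold higher number from compound 1 to compound 2 (0.73 log units; beyond the scatter).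

Compound 4, `Oc1nc2nonc2nc1Nc1ccccc1Cl`, has not yet been measured. Compared with compound 3 the change is chloro in place of trifluoromethyl on an aromatic carbon. Among the compounds with values here, the steps that bear on this are the ones that alter the same aromatic carbon. Exchanging fluoro for trifluoromethyl stayed within the scatter, while removing the group altogether moved the number beyond it in both comparisons. Chloro, like fluoro, is a halogen, so compound 4 is expected to behave like compounds 1 and 3 rather than like compound 2. For compound 4 the expected step is a 1.1-fold lower number from compound 3 to compound 4 (0.03 log units; within the scatter), nothing beyond the scatter. The estimated value for compound 4 is 10000 nM, with a range from 4000 nM to 25000 nM.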

Compound 4, half-maximal effective concentration: 6300 nM
Beside the measured number, compound 4's estimate is 1.6-fold (0.20 log units) above it, within the range that was stated.
By their numbers in this assay, from the lowest: compounds 4, 3 and 1 (each within the scatter of the next); then compound 2.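

Chloro now joins fluoro and trifluoromethyl as a group that this aromatic carbon tolerates without a readable change in this assay: there is a 1.7-fold lower number from compound 3 to compound 4 (0.23 log units; within the scatter) and a 2.0-fold lower number from compound 1 to compound 4 (0.30 log units; within the scatter), so compounds 1, 3 and 4 cannot be told apart. Within the data shown here, replacing trifluoromethyl, with its 4 heavy atoms, by chloro, with 1 heavy atom, therefore leaves the number within the scatter, whereas hydrogen remains the one clear exception: there is an 11-fold lower number from compound 2 to compound 4 (1.02 log units; beyond the scatter), the first step at this position to count as large. Nothing available explains why these three groups give such similar numbers or why compound 2 stands apart from them.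

The compounds shown vary only this one aromatic carbon, so it remains open whether a methyl, methoxy, amine or carboxylic acid group there would fall with the three halogen-bearing compounds or with compound 2. As far as these compounds go, it is also open whether chloro, fluoro and trifluoromethyl would remain indistinguishable if they were placed on a different carbon of the same ring.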